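Swapping an amino for a nitro group on compound 1

This account rests on a few compounds, and the source may have more. Where it says the series, first, only, none or still open, it means among the compounds named here.

Compound 1 `COc1ccc(-c2cc3nccc(-c4cc(OC)c(OC)c(OC)c4)n3n2)cc1N` is the most potent of the three measured compounds in a functional assay on MCF7 cells (Homo sapiens) for inhibition, read by CCK-8 assay, with a stated time of 48 h (on this read-out lower numbers stand for stronger inhibition and higher numbers for weaker inhibition), where compound 1 gives 27 nM. Compound 2 `COc1cc(-c2ccnc3cc(-c4ccc(C)cc4)nn23)cc(OC)c1OC` gives 47 nM, and the move is a 1.7-fold higher number from compound 1 to compound 2 (0.24 log units; within the scatter). Compound 3 `COc1cc(-c2ccnc3cc(-c4ccc(Cl)cc4)nn23)cc(OC)c1OC` gives 2320 nM, so an 86-fold higher number from compound 1 to compound 3 (1.93 log units; beyond the scatter) and a 49-fold higher number from compound 2 to compound 3 (1.69 log units; beyond the scatter).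

Among the measured compounds shown here, compound 4 `COc1ccc(-c2cc3nccc(-c4cc(OC)c(OC)c(OC)c4)n3n2)cc1[N+](=O)[O-]` keeps the shared core of compound 1 and changes only one group: nitro in place of amino on an aromatic carbon. For the measured compounds named here, none of the measured steps tests this change directly; the two large steps exchange the whole side ring rather than a single group on it, and the one small step also replaces the entire ring. So the measured data give no firm direction, only a warning that a single change on this ring can be large or small. Compound 4 is therefore expected to sit somewhat weaker than compound 1, with wide uncertainty, estimated at 120 nM with a range of 25 nM to 600 nM, meaning an expected 4.4-fold higher number from compound 1 to compound 4 (0.65 log units; beyond the scatter).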

Compound 4, half-maximal inhibitory concentration: > 10000 nM
Compound 4: a limit, no number; the forecaster's own chance of this, stated with the estimate: 5%; at least 83-fold (1.92 log units) between middle value and limit.
By their numbers in this assay, from the lowest: compounds 1 and 2 (each within the scatter of the next); then compound 3. At a limit, above all of these: compound 4.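

Placing nitro instead of amino on the aromatic carbon ortho to a methoxy group gives an at least 370-fold higher number from compound 1 to compound 4 (2.56 log units; beyond the scatter), the first single-group change at this position among the compounds shown, and it is large. Compound 4 gives a limit and no number in this assay: the limit of > 10000 nM in this assay, at which 1 of the 4 values shown sits. The side ring does not need the amino group to keep a low number, since a 4-methylphenyl ring in its place gives a 1.7-fold higher number from compound 1 to compound 2 (0.24 log units; within the scatter), so the nitro group's arrival, rather than the amino group's departure alone, goes with the loss here.

The compounds shown do not tell what it is about the nitro group that goes with this loss. Also open, going by these compounds, is where groups such as hydroxyl, methylamino or acetamide would fall at this position.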